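The source may report more compounds than this note shows. Statements on the series, on what has been measured and on what is new or still open speak of the compounds shown alone.

In a physicochemical assay for lipophilicity, measured as octanol-water partition (on this read-out lower numbers stand for lower lipophilicity and higher numbers for higher lipophilicity), compound 1 `CC1=C(C(=O)OCc2cccnc2)C(c2ccccc2)C2=C(CCCC2=O)N1` gives 2.35 and compound 2 `CCCC1C(C(=O)OCc2cccnc2)=C(C)NC2=C1C(=O)CCC2` gives 2.23, so the two stand within the scatter of each other. Compound 3 `CC1=C(C(=O)OCc2ccccn2)C(c2ccccc2)C2=C(CCCC2=O)N1` has pyridin-2-yl in place of pyridin-3-yl on a saturated chain carbon bound to an oxygen next to a carbonyl group. For the measured compounds named here, the only measured step, a number 0.12 log units lower from compound 1 to compound 2 (within the scatter), swaps phenyl for propyl at a different place, so it bears on this change only loosely. Going by the values given here, no measured step covers this change directly. In this assay the expected step is no change at the digits printed from compound 1 to compound 3 (within the scatter), with nothing expected beyond the scatter. The estimate for compound 3 is 2.35, within an expected range from 1.95 to 2.75.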

Compound 3, partition coefficient: 2.72
Beside the measured number, compound 3's estimate is 0.37 log units below it; measured number inside the range.
By their numbers in this assay, from the lowest: compounds 2 and 1 (each within the scatter of the next); then compound 3.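

In this assay, pyridin-2-yl in place of pyridin-3-yl on a saturated chain carbon bound to an oxygen next to a carbonyl group gives a number 0.37 log units higher from compound 1 to compound 3 (beyond the scatter). This place therefore responds to a swap that keeps the same atoms and the same counts of hydrogen-bond donors and acceptors, since only the way the atoms are joined differs. Nothing available here accounts for the shift.

The compounds shown leave open whether the same swap gives a similar step with propyl in place of phenyl, as in compound 2. They also leave open what an amine or a carboxylic acid on the pyridine ring would do to the number.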